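A few compounds are considered here, and "the series" means these few. Any claim that something is new, unique, unknown or untested is made for them only; others in the source may bear on it.

In a functional assay on A549 cells (Homo sapiens) for cytotoxicity, read by MTT assay, with a stated time of 72 h (a lower number here means a stronger inhibitor, a higher number a weaker inhibitor), three related compounds have been measured. Compound 1 (`Cc1ccc(Cn2cc(/C=N/NC(=O)Nc3nc4ccc(CN5CCC(C)CC5)cc4s3)c3ccccc32)cc1`) gives 2180 nM, compound 2 (`CN(C)Cc1ccc2nc(NC(=O)N/N=C/c3c[nH]c4ccccc34)sc2c1`) gives 3300 nM and compound 3 (`CN(C)Cc1ccc2nc(NC(=O)N/N=C/c3cn(Cc4ccccc4)c4ccccc34)sc2c1`) gives 2900 nM. Compound 3 is not separated from either of the others, as its gaps to both lie within the scatter.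

Compound 4 (`Cc1ccc(Cn2cc(/C=N/NC(=O)Nc3nc4ccc(CN(C)C)cc4s3)c3ccccc32)cc1`) differs from compound 3 by one small change, methyl in place of hydrogen on an aromatic carbon, turning benzyl into 4-methylbenzyl. Among the measured compounds shown here, the only measured step that touches this part of the molecule is the addition of the benzyl group itself, a 1.1-fold lower number from compound 2 to compound 3 (0.06 log units; within the scatter), and it stays within the scatter. Compound 1 already carries the 4-methylbenzyl group but also differs from compound 4 elsewhere in the structure, so it offers no clean comparison. Compound 1 at 2180 nM still falls within the scatter of compound 3.

For the measured compounds named here, with no measured step of any size at this position, no shift beyond the scatter is expected in this assay. The expected change is a 1.1-fold lower number from compound 3 to compound 4 (0.05 log units; within the scatter), which would stay within the scatter. Compound 4 is estimated at 2600 nM, with an expected range of 1500 nM to 4500 nM.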

Compound 4, half-maximal inhibitory concentration: 1600 nM
The estimate for compound 4 lay 1.6-fold (0.21 log units) above the measured number; measured number inside the range.
By their numbers in this assay, from the lowest: compounds 4, 1, 3 and 2 (each within the scatter of the next, the first and the last beyond it).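

In this assay, the methyl on the six-membered aromatic ring, para to a large group, gives a 1.8-fold lower number from compound 3 to compound 4 (0.26 log units; within the scatter) and so cannot be separated from the scatter on its own. Among the compounds shown here, measured from the unsubstituted aromatic nitrogen, however, 4-methylbenzyl gives a 2.1-fold lower number from compound 2 to compound 4 (0.31 log units; beyond the scatter) and is the first group at this nitrogen to pass the scatter, if only modestly, whereas benzyl gave a 1.1-fold lower number from compound 2 to compound 3 (0.06 log units; within the scatter) and did not. With 4-methylbenzyl in place, dimethylamino instead of 4-methylpiperidin-1-yl gives a 1.4-fold lower number from compound 1 to compound 4 (0.13 log units; within the scatter) and remains within the scatter, so the compounds that carry this group are not separated by that change in the amine.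

The compounds shown leave open whether a chlorine, a methoxy group or a longer chain such as ethyl at the same place on the benzyl ring would move the number further from that of compound 2, and whether the small gain seen with the methyl would hold up on repeated measurement. Nothing measured here gives a reason for any of these steps.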